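Methyl to Hydrogen on the Phenol Oxygen: an Expected Step

The compounds below may be only part of what the source reports. "The series", "measured", "known", "first", "only" and "open" are said of these compounds alone.

Compound 1 `Cc1cc(O)cc(-c2nn(CC#N)cc2-c2ccnc(-c3ccc(Oc4ccccc4)cc3)c2)c1` gives 1870 nM in a functional assay on NCI-H460 cells (Homo sapiens) for inhibition, read by sulforhodamine B assay, with a stated time of 48 h; on this read-out lower numbers stand for stronger inhibition of growth and higher numbers for weaker inhibition of growth.
Compound 2 `COc1cc(C)cc(-c2nn(CC#N)cc2-c2ccnc(-c3ccc(N(C)C)cc3)c2)c1` gives 371 nM in this assay.

Among the compounds with values here, compound 2 holds the lowest of the two numbers in this assay; compound 1 is the only other measured member, and its number is higher by a margin that lies beyond the usual scatter. Compound 3 `Cc1cc(O)cc(-c2nn(CC#N)cc2-c2ccnc(-c3ccc(N(C)C)cc3)c2)c1` has not yet been measured. It differs from compound 2 in one place: hydrogen in place of methyl on an oxygen on an aromatic ring. Within the data shown here, no measured pair shows this exact change on its own, so the size of the step is open. Compound 3 shares its hydroxy-bearing ring with compound 1 and its dimethylamino-bearing ring with compound 2. On that basis a modest step in this assay is expected, if any, leaning toward a slightly higher number: the expected step is a 1.5-fold higher number from compound 2 to compound 3 (0.17 log units; within the scatter). Compound 3 is therefore estimated at 550 nM, with a range from 170 nM to 1800 nM.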

Compound 3, concentration for 50% growth inhibition: 2790 nM
Beside the measured number, compound 3's estimate is 5.1-fold (0.71 log units) below it; the measured number lies above the stated range.
By their numbers in this assay, from the lowest: compound 2; then compounds 1 and 3 (each within the scatter of the next).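

In this assay, within the data shown here, the methyl on the phenol oxygen proves to count at this position: methoxy to hydroxy on the 3-methoxy-5-methylphenyl group gives a 7.5-fold higher number from compound 2 to compound 3 (0.88 log units; beyond the scatter), the first reading of this change on its own, and it lies beyond the scatter. With the 3-hydroxy-5-methylphenyl group held fixed, dimethylamino in place of phenoxy on an aromatic carbon gives a 1.5-fold higher number from compound 1 to compound 3 (0.17 log units; within the scatter), so that change lies within the scatter here. Nothing in the available data explains the size of the methoxy to hydroxy step.

The compounds shown leave open whether this step carries over when phenoxy stands in place of dimethylamino. They also leave open how a longer chain on that oxygen, such as ethyl, or an amine in place of the oxygen, would read.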